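The source may hold more compounds than are shown below. What is called first, only, known or untested is meant among the compounds shown, and "the series" means these compounds.

Measured in an ADME assay on cells (Epithelial cell, Rattus norvegicus) for cytotoxicity, read by MTT assay; a higher number here means a weaker inhibitor, a lower number a stronger inhibitor:
- compound 1 `O=C(Cn1c(=O)c(Cc2ccccc2)nc2ccccc21)NNC(=S)Nc1ccccc1`: 16.1 nM
- compound 2 `O=c1c(Cc2ccccc2)nc2ccccc2n1Cc1nnc(S)n1-c1ccccc1`: 7.78 nM
- compound 3 `O=C(Cn1c(=O)c(Cc2ccccc2)nc2ccccc21)N/N=C/c1ccccc1O`: 8.12 nM

Compound 3, at 8.12 nM, lies within the scatter of both other compounds, so the numbers give it no distinct rank.

The next compound is compound 4 `Cc1ccc(C(=O)NNC(=O)Cn2c(=O)c(Cc3ccccc3)nc3ccccc32)cc1`. Its change from compound 3 is a group of 10 heavy atoms (8 carbon, 1 nitrogen, 1 oxygen; one six-membered aromatic ring of carbon only) in place of a group of 9 heavy atoms (7 carbon, 1 nitrogen, 1 oxygen; one six-membered aromatic ring of carbon only), on an amide-type nitrogen. The entering group is ((4-methylphenyl)carbonyl)amino, on an amide-type nitrogen whose other neighbour is a carbonyl carbon.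

Going by the values given here, only one measured step bears on this change, as it exchanges a group at the same kind of nitrogen: a 2.0-fold lower number from compound 1 to compound 3 (0.30 log units; within the scatter). That single step stayed within the scatter, although the exchanged groups differ. There is no measured case for the entering group itself, so the basis is thin and no direction can be supported.

The expected change, a 1.2-fold higher number from compound 3 to compound 4 (0.09 log units; within the scatter), is estimated to remain within the scatter. For compound 4 the expected value is 10 nM, with an estimated range of 4 nM to 25 nM.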

Compound 4, half-maximal inhibitory concentration: 49.7 nM
For compound 4 the middle estimate is 5.0-fold (0.70 log units) below the measured one; the measured number lies above the stated range.
By their numbers in this assay, from the lowest: compounds 2, 3 and 1 (each within the scatter of the next, the first and the last beyond it); then compound 4.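

In this assay, going by these compounds alone, the amide-type nitrogen responds to the group it carries, with a 6.1-fold higher number from compound 3 to compound 4 (0.79 log units; beyond the scatter) as the first step at this place beyond the scatter. A second step, a 3.1-fold higher number from compound 1 to compound 4 (0.49 log units; beyond the scatter) on an amine nitrogen, points the same way although the group that leaves is different. No measured evidence bears on the reason for either step.

It remains open which part of the ((4-methylphenyl)carbonyl)amino group carries the rise, as the compounds shown do not separate the methyl from the carbonyl or the aromatic ring. A methoxy in place of the methyl, or a simple acetyl in place of the whole aromatic carbonyl group, would help to settle this.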